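A few compounds are considered here, and "the series" means these few. Any claim that something is new, unique, unknown or untested is made for them only; others in the source may bear on it.

Of the compounds shown here, three on a shared core have numbers so far in an ADME assay (liver) for metabolic stability, with Liver microsome (Homo sapiens) as the target, read by LC-MS, using microsomes, with a stated time of 30 min, tested at 4 uM (on this read-out lower numbers stand for a less stable compound and higher numbers for a more stable compound), and they spread widely. Compound 1 (`CC(=O)NCCn1c(-c2ccccc2Cl)nc2c(N3CCN(C)CC3)nc(C)nc21`) gives 0% here, compound 2 (`CCN1CCN(c2nc(C)nc3c2nc(-c2ccccc2Cl)n3CC2CCOCC2)CC1`) gives 41% here, and compound 3 (`Cc1nc(N2CCN(C)CC2)c2nc(-c3cccc(Cl)c3)n(C3CCOCC3)c2n1`) gives 25% here. Compound 3 is therefore the second highest of the three, lying under compound 2 and over compound 1, with both gaps beyond the usual scatter.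

The next compound to be read is compound 4 (`Cc1nc(N2CCN(C)CC2)c2nc(-c3ccccc3C3CC3)n(C3CCOCC3)c2n1`), which has 2-cyclopropylphenyl in place of 3-chlorophenyl on an aromatic carbon next to the ring atom that bears an oxan-4-yl group. The measured compounds differ from one another in several places at once, so none of them shows what this swap alone does. Taking compound 3 at 25% as the starting point, only a small fall is expected, and with little confidence in its direction. The estimated change is a number 7 percentage points lower from compound 3 to compound 4 (within the scatter) and it may not be distinguishable from repeat noise. The estimated value for compound 4 is 18% with an expected range of 4% to 38% as the likely span.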

Compound 4, percent of the compound remaining: 33%
Compound 4: middle estimate off by 15 percentage points, on the low side, and the stated range covers the measured number.
By their numbers in this assay, from the lowest: compound 1; then compounds 3, 4 and 2 (each within the scatter of the next, the first and the last beyond it).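

In this assay, going by these compounds alone, 2-cyclopropylphenyl in place of 3-chlorophenyl on this aromatic carbon gives a number 8 percentage points higher from compound 3 to compound 4 (within the scatter), the first step that isolates a single change. At this position, then, the chlorine can give way to a three-membered carbon ring, with the attachment point on the phenyl ring also differing, and the read-out stays within repeat noise. Nothing measured here bears on why the two compounds read alike.

On these data alone, this single step cannot separate the effect of the group from the effect of where it sits on the phenyl ring, so the contribution of each remains open. Plain phenyl or 2-methoxyphenyl on this same carbon would test whether the stability reading depends on what the phenyl ring carries at all.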